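This account rests on a few compounds, and the source may have more. Where it says the series, first, only, none or still open, it means among the compounds named here.

Within the data shown here, compound 2 `COc1ccc2c(=O)c(/C=C/C(=O)Nc3ccccc3)coc2c1` gives 51000 nM in a functional assay on A549 cells (Homo sapiens) for inhibition, read by MTT assay, with a stated time of 48 h (a higher number here means a weaker inhibitor, a lower number a stronger inhibitor), the only numeric value in the set. Compound 1 `O=C(/C=C/c1coc2cc(O)ccc2c1=O)NCc1ccc(F)cc1` is reported in this assay only as a limit, > 100000 nM (the limit of > 100000 nM in this assay, at which 1 of the 2 values shown sits). Compound 3 `COc1ccc2c(=O)c(/C=C/C(=O)NCc3ccccc3)coc2c1` differs from compound 2 by benzyl in place of phenyl on an amide-type nitrogen. Among the measured compounds shown here, no measured step covers this change; compound 1 also carries benzyl on an amide-type nitrogen, but its core differs from that of compound 2 as well, so the pair shows only its two values. A step from compound 2 to compound 3 of a 1.6-fold higher number from compound 2 to compound 3 (0.20 log units; within the scatter) toward weaker inhibition is expected. Compound 3 is estimated at 80000 nM, within 30000 nM to 200000 nM.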

Compound 3, half-maximal inhibitory concentration: 11800 nM
Compound 3: the middle estimate sits 6.8-fold (0.83 log units) above what was measured, and the stated range ends above it.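

On the amide-type nitrogen, benzyl in place of phenyl gives a 4.3-fold lower number from compound 2 to compound 3 (0.64 log units; beyond the scatter), so in this assay this position responds to the change, toward stronger inhibition. Among these compounds, this is the only measured step at this nitrogen on the shared core: compound 1 also carries benzyl there, but its core differs and its result is only a limit. No measured property accounts for the step. Open, on these data alone, is whether phenethyl on the same nitrogen extends this gain, and whether a benzyl carrying an amine or a carboxylic acid keeps it.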